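The source may report more compounds than this note shows. Statements on the series, on what has been measured and on what is new or still open speak of the compounds shown alone.

In a functional assay on MKN-45 cells (Homo sapiens) for cytotoxicity, read by MTT assay, with a stated time of 72 h (on this read-out higher numbers stand for weaker inhibition and lower numbers for stronger inhibition), three compounds of a shared core have been measured. Compound 1, `COc1cc2c(Oc3ccc(NC(=O)c4nn(-c5ccccc5F)c(=O)c5ccccc45)cc3F)ccnc2cc1OCCCN1CCN(C)CC1`, gives 210 nM. Compound 2, `COc1cc2c(Oc3ccc(NC(=O)c4nn(-c5ccc(Br)cc5)c(=O)c5ccccc45)cc3F)ccnc2cc1OCCCN1CCN(C)CC1`, differs from compound 1 by 4-bromophenyl in place of 2-fluorophenyl on an aromatic nitrogen, and on this read-out compound 2 gives 350 nM, so that a 1.7-fold higher number from compound 1 to compound 2 (0.22 log units; within the scatter). Compound 3, `COc1cc2c(Oc3ccc(NC(=O)c4nn(-c5ccccc5F)c(=O)c5ccccc45)cc3F)ccnc2cc1OCCCN1CCC(C)CC1`, carries a different tail: 4-methylpiperidin-1-yl in place of 4-methylpiperazin-1-yl on a saturated chain carbon, three bonds along the chain from an oxygen on an aromatic ring. In this assay compound 3 gives 260 nM, and a 1.2-fold higher number from compound 1 to compound 3 (0.09 log units; within the scatter).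

Compound 4, `COc1cc2c(Oc3ccc(NC(=O)c4nn(-c5ccc(Br)cc5)c(=O)c5ccccc45)cc3F)ccnc2cc1OCCCN1CCC(C)CC1`, has not yet been measured. It combines the tail of compound 3 with the aryl group of compound 2, so that compound 4 differs from compound 3 by 4-bromophenyl in place of 2-fluorophenyl on an aromatic nitrogen. Going by the values given here, this is the same change as the one made from compound 1 to compound 2, made at the same place, and the only difference between the pair of cores is the one described between compound 1 and compound 3. Since both changes already measured stayed within the scatter, the account expects the step from compound 3 to compound 4 in this assay to be a 1.7-fold higher number from compound 3 to compound 4 (0.23 log units; within the scatter), resting on the earlier observation that a 1.7-fold higher number from compound 1 to compound 2 (0.22 log units; within the scatter). On that basis compound 4 is estimated to give about 440 nM in this assay, most likely somewhere between 250 nM and 800 nM.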

Compound 4, half-maximal inhibitory concentration: 330 nM
Compound 4: the middle estimate sits 1.3-fold (0.12 log units) above what was measured, and the stated range covers the measured number.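

In this assay, 4-bromophenyl in place of 2-fluorophenyl on the aromatic nitrogen now gives a 1.3-fold higher number from compound 3 to compound 4 (0.10 log units; within the scatter), and this step agrees with the one seen on the core of compound 1: the same change on two cores in this assay, a 1.7-fold higher number (0.22 log units; within the scatter) from compound 1 to compound 2 and a 1.3-fold higher number (0.10 log units; within the scatter) from compound 3 to compound 4, 1.3-fold (0.12 log units) apart, within the scatter of two such steps

The tail change, 4-methylpiperidin-1-yl in place of 4-methylpiperazin-1-yl, gives a 1.1-fold lower number from compound 2 to compound 4 (0.03 log units; within the scatter), and it also agrees across the two cores: the same change on two cores in this assay, a 1.2-fold higher number (0.09 log units; within the scatter) from compound 1 to compound 3 and a 1.1-fold lower number (0.03 log units; within the scatter) from compound 2 to compound 4, 1.3-fold (0.12 log units) apart, within the scatter of two such steps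

Across these four compounds, then, each change gave a comparable result on both cores, but every step lies within the scatter, so this does not show that either change has a real effect of its own, and agreement between such small steps is only a weak test of whether a change carries from one core to another.

The compounds shown leave open whether a change that moves the number beyond the scatter would carry over in the same way, for instance a morpholine or a dimethylamine in place of the tail, or a pyridine ring in place of the aryl group on the nitrogen. They also leave open how the halogen and its place on the ring count separately, which a 4-fluorophenyl or a 2-bromophenyl group could help to tell apart.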